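The compounds below may be only part of what the source reports. "The series", "measured", "known", "first", "only" and "open" are said of these compounds alone.

Measured compounds in a functional assay on HepG2 cells (Homo sapiens) for antiproliferative activity, read by MTT assay; on this read-out higher numbers stand for weaker inhibition and lower numbers for stronger inhibition:
Compound 1, `CNC(=O)c1ccc(Oc2cccc(NC(=S)Nc3ccc(OC(F)(F)F)cc3)c2)nc1` — compound 1 gives > 100000 nM, which is a limit of the assay and not a number.
Compound 2, `CNC(=O)c1ccc(Oc2cccc(NC(=S)Nc3cc(C(F)(F)F)cc(C(F)(F)F)c3)c2)nc1` — compound 2 gives 4550 nM.
Compound 3, `CNC(=O)c1ccc(Oc2cccc(NC(=S)Nc3ccc(F)c(C(F)(F)F)c3)c2)nc1` — compound 3 gives 20200 nM.

All three share the same core and differ only in the substituents on the outer aromatic ring of the thiourea. Of the two numbers available in this assay, compound 3 stands highest; its nearest neighbour is compound 2, whose number is lower by a margin beyond the usual scatter. For compound 1 the assay reports only a limit, so its place relative to the others cannot be fixed.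

Compound 4, `CNC(=O)c1ccc(Oc2cccc(NC(=S)Nc3ccc(F)c(F)c3)c2)nc1`, has not yet been measured in this assay. It differs from compound 3 by fluoro in place of trifluoromethyl on an aromatic carbon.

Among the compounds with values here, no pair of measured compounds shows this particular change, so its effect must be estimated. On the numbers seen so far, the compounds with fewer fluorinated groups on that ring do not give lower numbers, and compound 4 is therefore expected to move toward weaker inhibition, with the step of a 2.2-fold higher number from compound 3 to compound 4 (0.35 log units; beyond the scatter) judged likely to exceed the scatter. Compound 4 is estimated at 45000 nM, within a range from 12000 nM to 120000 nM, with a real chance that only a limit is reported.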

Compound 4, half-maximal inhibitory concentration: 26700 nM
For compound 4 the middle estimate is 1.7-fold (0.23 log units) above the measured one, within the range that was stated.
By their numbers in this assay, from the lowest: compound 2; then compounds 3 and 4 (each within the scatter of the next). At a limit, above all of these: compound 1.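

In this assay, the swap of trifluoromethyl for fluoro on this aromatic carbon, ortho to a fluoro group, gives a 1.3-fold higher number from compound 3 to compound 4 (0.12 log units; within the scatter). Within the data shown here, this is the first change that can be read in one place alone, since the earlier compounds differ from each other in more than one place on the outer ring. It shows that going from a group of 4 heavy atoms to a group of 1 at this position leaves the two compounds within the scatter of each other, so on this read-out the two groups cannot be told apart here, and nothing shown gives a reason for that.

Going by these compounds, what a group of a different kind would do on this same carbon stays open: an amine, a carboxylic acid or a methoxy group might separate from the two numbers seen here, or might not. Also open, on these data alone, is whether the same swap would give a similar step with hydrogen in place of the fluoro group to which this position is ortho, since the step is known in this one setting only.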